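The source may hold more compounds than are shown below. What is called first, only, known or untested is meant among the compounds shown, and "the series" means these compounds.

Measured in an ADME assay on Vero cells (Chlorocebus sabaeus) for inhibition, read by sulforhodamine B assay, with a stated time of 48 h; on this read-out lower numbers stand for stronger inhibition of growth and higher numbers for weaker inhibition of growth:
compound 1 `CC1=CC[C@H](C(C)(C)NC(=S)NN)CC1` gives > 100000 nM, a limit of the assay.
compound 2 `COc1ccc(/C=N/NC(=S)NC(C)(C)[C@H]2CC=C(C)CC2)cc1` gives 70100 nM.
compound 3 `CC1=CC[C@H](C(C)(C)NC(=S)N/N=C/c2ccccc2Cl)CC1` gives > 100000 nM, a limit of the assay and not a number.

Compound 3 thus stands at the limit of > 100000 nM in this assay, at which 2 of the 3 values shown sit. Among the compounds with values here, the only measured step at the carbon with a double bond to nitrogen is an at least 1.4-fold higher number from compound 2 to compound 3 (0.15 log units; that floor lies within the scatter), which ran from a measured number into the limit. Compound 4 `CC1=CC[C@H](C(C)(C)NC(=S)N/N=C/c2ccco2)CC1` differs from compound 3 by furan-2-yl in place of 2-chlorophenyl on a carbon with a double bond to nitrogen. Within the data shown here, no measured step involves a furan-2-yl group, so nothing points to a change beyond the scatter in this assay. The expected step is a number no higher from compound 3 to compound 4 (the limit leaves the size open), none beyond the scatter. Compound 4 is therefore estimated at 100000 nM, with a range from 40000 nM to 250000 nM.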

Compound 4, concentration for total growth inhibition: 14700 nM
Beside the measured number, compound 4's estimate is 6.8-fold (0.83 log units) above it; measured number below the stated range.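

In this assay, within the data shown here, furan-2-yl on the carbon with a double bond to nitrogen gives the first change at this place that is clearly beyond the scatter: an at least 6.8-fold lower number from compound 3 to compound 4 (0.83 log units; beyond the scatter), and a 4.8-fold lower number from compound 2 to compound 4 (0.68 log units; beyond the scatter). The same group also separates this series from the parent, with an at least 6.8-fold lower number from compound 1 to compound 4 (0.83 log units; beyond the scatter). Among these compounds, only the step from compound 2 has a measured size, as the other two start from a limit of the assay.

The compounds shown leave open whether this step follows the ring oxygen or the five-membered ring. A thiophen-2-yl or an unsubstituted phenyl group at this place would bear on that.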